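The source may hold more compounds than are shown below. What is called first, only, known or untested is meant among the compounds shown, and "the series" means these compounds.

Compound 1 `COc1cc2c(/C=C3/C(=O)N(C)c4ccccc43)c(Cl)n(C)c2cc1C`: 13200 nM
Compound 2 `COc1cc2c(/C=C3/C(=O)N(C)c4ccccc43)c[nH]c2cc1C`: 55000 nM

In a functional assay on cells (Cancer cell lines, Homo sapiens) for inhibition, with a stated time of 48 h (on this read-out lower numbers stand for stronger inhibition of growth and higher numbers for weaker inhibition of growth), compound 2 has the higher of the two numbers at 55000 nM, so it is the weaker growth inhibitor, while compound 1 gives 13200 nM, a gap beyond the scatter. Compound 3 `COc1cc2c(/C=C3/C(=O)N(C)c4ccc(O)cc43)c[nH]c2cc1C` differs from compound 2 in one place: hydroxy in place of hydrogen on an aromatic carbon, with hydroxy in place of hydrogen on an aromatic carbon. For the measured compounds named here, no measured pair shows the effect of this change, so any forecast is uncertain. A small expected step, a 1.4-fold lower number from compound 2 to compound 3 (0.16 log units; within the scatter), points towards a lower number and stays within the scatter. The estimated value for compound 3 is 38000 nM, with an expected range from 14000 nM to 100000 nM.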

Compound 3, concentration for total growth inhibition: 16200 nM
For compound 3 the middle estimate is 2.3-fold (0.37 log units) above the measured one, within the range that was stated.
By their numbers in this assay, from the lowest: compounds 1 and 3 (each within the scatter of the next); then compound 2.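

In this assay, the six-membered aromatic ring of carbon only tolerates a change at this position: hydroxy in place of hydrogen gives a 3.4-fold lower number from compound 2 to compound 3 (0.53 log units; beyond the scatter) and so a modest gain in growth inhibition. This single step therefore shows that adding one hydroxy group here strengthens inhibition rather than weakens it. Going by these compounds, whether an amine or a carboxylic acid at the same position would do likewise remains open. The data available offer no explanation for the step.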